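Nitro position change on the anilino ring of the series

The source may report more compounds than this note shows. Statements on the series, on what has been measured and on what is new or still open speak of the compounds shown alone.

Compound 1 `CCN(CC)c1nc(Nc2cccc(C(=O)O)c2)nc(OC(C(F)(F)F)C(F)(F)F)n1` gives 160 nM in an assay on cells for activation of Cystic fibrosis transmembrane conductance regulator (Homo sapiens), read by fluorescence, with stated times of 10 min and 12 s; a lower number here means that less compound is needed, a higher number that more compound is needed for the effect. Compound 2 `CCN(CC)c1nc(Nc2cccc([N+](=O)[O-])c2)nc(OC(C(F)(F)F)C(F)(F)F)n1` gives 200 nM; the step of a 1.3-fold higher number from compound 1 to compound 2 (0.10 log units; within the scatter) leaves the two within the scatter of each other, so compound 2 sits alongside compound 1 with no separation. Compound 3 `CCN(CC)c1nc(Nc2ccc([N+](=O)[O-])cc2)nc(OC(C(F)(F)F)C(F)(F)F)n1` differs from compound 2 only by 4-nitrophenyl in place of 3-nitrophenyl on a nitrogen on an aromatic ring. Among the compounds with values here, no measured step moves the nitro group on the ring, so nothing here bears directly on this change, and only the small carboxy-to-nitro step is available as context. The step of a 1.3-fold higher number from compound 2 to compound 3 (0.10 log units; within the scatter) is expected to stay within the scatter. Compound 3 is estimated at 250 nM, between 80 nM and 800 nM.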

Compound 3, half-maximal effective concentration: 18000 nM
The estimate for compound 3 lay 72-fold (1.86 log units) below the measured number; measured number outside the range, above it.
By their numbers in this assay, from the lowest: compounds 1 and 2 (each within the scatter of the next); then compound 3.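

In this assay, the same atoms joined differently give a 90-fold higher number from compound 2 to compound 3 (1.95 log units; beyond the scatter), so this position tolerates 3-nitrophenyl but not 4-nitrophenyl on the nitrogen. The step of a 110-fold higher number from compound 1 to compound 3 (2.05 log units; beyond the scatter) is similarly large, whereas compound 1 and compound 2 stayed within the scatter, so in these compounds where the group sits counts for more than the exchange of carboxy for nitro. Nothing available explains the rise.

As far as these compounds go, whether a carboxylic acid or an amine in place of the nitro group of 4-nitrophenyl gives the same rise remains open.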